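Benzyl triazole series: hydroxy replaced by chloro

The source may report more compounds than this note shows. Statements on the series, on what has been measured and on what is new or still open speak of the compounds shown alone.

Compound 1 `O=C1N[C@H]2[C@H](CS[C@H]2CCCCCc2cn(Cc3ccccc3O)nn2)N1` is measured in an assay on isolated protein for inhibition of biotin--protein ligase (Homo sapiens), read by scintillation counting, with a stated time of 10 min (on this read-out lower numbers stand for stronger inhibition and higher numbers for weaker inhibition), where compound 1 gives only the limit > 16000 nM and no number. Compound 2 `O=C1N[C@H]2[C@H](CS[C@H]2CCCCCc2cn(Cc3ccccc3F)nn2)N1` likewise gives only the limit > 16000 nM in this assay. Compound 3 `O=C1N[C@H]2[C@H](CS[C@H]2CCCCCc2cn(Cc3cccc(F)c3)nn2)N1` in this assay also gives only the limit > 16000 nM. All three values sit at the limit of > 16000 nM in this assay, at which 3 of the 3 values shown sit, so the steps a step that the two limits leave unreadable from compound 1 to compound 2, a step that the two limits leave unreadable from compound 1 to compound 3 and a step that the two limits leave unreadable from compound 2 to compound 3 have no readable size. Compound 4 `O=C1N[C@H]2[C@H](CS[C@H]2CCCCCc2cn(Cc3ccccc3Cl)nn2)N1` differs from compound 1 by chloro in place of hydroxy on an aromatic carbon. Among the measured compounds shown here, no measured step bears readably on this change; the fluoro analogues all remain at the limit. No step beyond the scatter is therefore expected for compound 4, which is estimated at 20000 nM with a range of 8000 nM to 60000 nM. The expected step is a step that the limit leaves unreadable from compound 1 to compound 4, most likely reported again as a limit.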

Compound 4, inhibition constant: > 16000 nM
Compound 4 was reported as a limit; the forecaster's own chance of this, stated with the estimate: 85%; the middle value lies beyond the limit too.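

The steps from compound 4 to compounds 1, 2 and 3 cannot be read, as all four compounds give only a limit: the limit of > 16000 nM in this assay, at which 4 of the 4 values shown sit. The compounds shown leave open how far these four actually differ in inhibition.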